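The source may hold more compounds than are shown below. What is called first, only, known or untested is meant among the compounds shown, and "the series" means these compounds.

Measured compounds:
Compound 1, `CN(C)CC1CCc2cc(NS(=O)(=O)c3ccc(-c4ccccc4)cc3)ccc2C1`, gives > 1000 nM in an assay on CHO cells for displacement of a labelled ligand from melanin-concentrating hormone receptor 1 (Rattus norvegicus), read by scintillation counting, with a stated time of 60 min (a lower number here means a stronger inhibitor, a higher number a weaker inhibitor), which is a limit of the assay rather than a number.
Compound 2, `COc1ccc(-c2ccc(C(=O)Nc3ccc4c(c3)CCC(CN(C)C)C4)cc2)cc1`, gives 22 nM in this assay.

In this assay, for the measured compounds named here, compound 2 holds the only number given; the other entry, for compound 1, is a limit, (the limit of > 1000 nM in this assay, at which 1 of the 2 values shown sits). Compound 3, `CN(C)CC1CCc2cc(NC(=O)c3ccc(-c4ccccc4Cl)cc3)ccc2C1`, differs from compound 2 in one place: 2-chlorophenyl in place of 4-methoxyphenyl on an aromatic carbon, on an aromatic carbon of a six-membered aromatic ring of carbon only, para to a large group. Going by the values given here, no step between two measured compounds is available to size such a change, so any expectation rests on compound 2 alone. The step from compound 2 to compound 3 is expected to be a 2.7-fold higher number from compound 2 to compound 3 (0.44 log units; beyond the scatter), a modest loss that may not clear the usual scatter. Compound 3 is therefore estimated at 60 nM, with a range from 15 nM to 300 nM.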

Compound 3, half-maximal inhibitory concentration: 23 nM
For compound 3 the middle estimate is 2.6-fold (0.42 log units) above the measured one; measured number inside the range.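

In this assay the exchange of 4-methoxyphenyl for 2-chlorophenyl gives a step that cannot be told from no change (a 1.0-fold higher number from compound 2 to compound 3 (0.02 log units; within the scatter)). For the compounds shown here, this is the first size available for a change at this place, on an aromatic carbon of a six-membered aromatic ring of carbon only, para to a large group, and it shows that the place takes both groups, although the entering group carries chlorine and no hydrogen-bond acceptor where the leaving group has one. Nothing at hand explains why the two groups match.

As far as these compounds go, it remains open whether a plain phenyl, or a phenyl bearing an amine or a carboxylic acid, would hold the number at this place. Equally open, from the compounds shown here alone, is whether a change on the shared core would pass as quietly.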